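Thienopyridine carboxamides: bromo to methyl on the benzoyl ring

The compounds below may be only part of what the source reports. "The series", "measured", "known", "first", "only" and "open" are said of these compounds alone.

Measured so far:
compound 1, `NC(=O)c1c(NC(=O)c2ccccc2Cl)sc2c1CCN(Cc1cc(Cl)cc(Cl)c1)C2`, 19600 nM
compound 2, `Cc1ccc(C(=O)Nc2sc3c(c2C(N)=O)CCN(Cc2c(Cl)cccc2Cl)C3)cc1`, 47400 nM
compound 3, `NC(=O)c1c(NC(=O)c2ccccc2Br)sc2c1CCN(C(=S)Nc1ccccc1Cl)C2`, 46900 nM

All three were run in a functional assay on HeLa cells (Homo sapiens) for antiproliferative activity, with a stated time of 24 h; a lower number here means a stronger inhibitor, a higher number a weaker inhibitor. Compound 3 stands second highest of the three numbers. Compound 2 gives 47400 nM, which lies within the scatter of compound 3, so no order between the two can be read. Compound 1 gives 19600 nM, a lower number than compound 3 and beyond the scatter; compound 1 also differs from compound 3 at two places, so nothing is attributed to either.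

Compound 4, `Cc1ccccc1C(=O)Nc1sc2c(c1C(N)=O)CCN(C(=S)Nc1ccccc1Cl)C2`, differs from compound 3 in one place: methyl in place of bromo on an aromatic carbon. Among the measured compounds shown here, no measured pair isolates this exchange. Compound 2, the only other carrier of a methyl on the benzoyl ring, sits at a different position and with a different substituent on the saturated ring nitrogen, so it gives no direct guide. With the rest of the molecule unchanged, the expected step in this assay from compound 3 to compound 4 is a 1.1-fold higher number from compound 3 to compound 4 (0.03 log units; within the scatter), that is none beyond the scatter. Compound 4 is therefore estimated at 50000 nM, in the range 20000 nM to 125000 nM.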

Compound 4, half-maximal inhibitory concentration: 35300 nM
Compound 4: the middle estimate sits 1.4-fold (0.15 log units) above what was measured; low and high end bracket the measured number.
By their numbers in this assay, from the lowest: compounds 1, 4, 3 and 2 (each within the scatter of the next, the first and the last beyond it).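

In this assay, among the compounds shown here, the exchange of 2-bromophenyl for 2-methylphenyl gives a 1.3-fold lower number from compound 3 to compound 4 (0.12 log units; within the scatter), the only reading of this position with the rest of the molecule held fixed. Bromo and methyl, each on an aromatic carbon ortho to a large group, are therefore not told apart in this assay on this scaffold, something the earlier compounds, which differ in more than one place, could not show. No evidence on either group bears on this result.

Open, going by these compounds, is whether an amine, a carboxylic acid or a longer chain at this position would give a step beyond the scatter. For the compounds shown here, also open is whether bromo and methyl remain indistinguishable when the substituent on the saturated ring nitrogen is the one carried by compound 1 or compound 2.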